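The source may hold more compounds than are shown below. What is called first, only, known or untested is meant among the compounds shown, and "the series" means these compounds.

Measured compounds in a functional assay on HepG2 cells (Homo sapiens) for antiproliferative activity, read by MTT assay, with a stated time of 24 h; a higher number here means a weaker inhibitor, a lower number a stronger inhibitor:
compound 1 `Cc1ccc(-n2cc(-c3ccccc3NS(=O)(=O)c3c[nH]c(=O)[nH]c3=O)nn2)cc1`, compound 1 gives 8350 nM
compound 2 `O=c1[nH]cc(S(=O)(=O)Nc2cccc(-c3cn(-c4ccccc4)nn3)c2)c(=O)[nH]1`, compound 2 gives 11200 nM

Compound 2 holds the higher of the two numbers, but its gap to compound 1 lies within the scatter, so the two cannot be ordered. Among the compounds with values here, the two compounds differ in more than one place, so no single step between them is available.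

Compound 3 `Cc1cccc(-n2cc(-c3cccc(NS(=O)(=O)c4c[nH]c(=O)[nH]c4=O)c3)nn2)c1` differs from compound 2 by methyl in place of hydrogen on an aromatic carbon. Nothing measured here isolates this change. A small change of this kind is expected to give no step beyond the scatter in this assay, a 1.1-fold lower number from compound 2 to compound 3 (0.05 log units; within the scatter). Compound 3 is estimated at 10000 nM, with a range from 4000 nM to 25000 nM.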

Compound 3, half-maximal inhibitory concentration: 7050 nM
Compound 3: middle estimate off by 1.4-fold (0.15 log units), on the high side, and the stated range covers the measured number.
By their numbers in this assay, from the lowest: compounds 3, 1 and 2 (each within the scatter of the next).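

In this assay, within the data shown here, the change from phenyl to 3-methylphenyl gives a 1.6-fold lower number from compound 2 to compound 3 (0.20 log units; within the scatter), the first comparison that differs in one place only. A methyl on this aromatic carbon, meta to a large group, therefore produces no step beyond the scatter. No measured evidence here bears on the reason for this result.

Going by these compounds, whether an amine, a carboxylic acid or a longer chain at this same place would give a step beyond the scatter remains open. On these data alone, the effect of methyl at any other carbon of this ring also remains open.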